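The source may report more compounds than this note shows. Statements on the series, on what has been measured and on what is new or still open speak of the compounds shown alone.

Measured compounds:
compound 1, `CC1(C)[C@@H]2CC[C@@]1(CS(=O)(=O)N1CCN(c3ncc(C(F)(F)F)cn3)CC1)C(=O)C2`, gives 316 nM;
compound 2, `CC1(C)[C@@H]2CC[C@@]1(CS(=O)(=O)N1CCN(c3ccc(C(F)(F)F)cn3)CC1)C(O)C2`, gives 158 nM;
compound 3, `CC1(O)C[C@H]2CC[C@]1(CS(=O)(=O)N1CCN(c3ccc(C(F)(F)F)cn3)CC1)C2(C)C`, gives 200 nM.

All three were tested in a functional assay on CHO-K1 cells for antagonist activity at C-X-C chemokine receptor type 3 (Homo sapiens), read by FLIPR and calcium flux; on this read-out higher numbers stand for weaker inhibition and lower numbers for stronger inhibition. Compound 2 and compound 3 share one core and differ by methyl in place of hydrogen on a saturated ring carbon. That change gave a 1.3-fold higher number from compound 2 to compound 3 (0.10 log units; within the scatter). The difference between the core of compound 1 and the core of compound 2 is not broken down here; compound 1 and compound 2 differ in more than one place.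

Compound 4, `C[C@H]1CN(S(=O)(=O)C[C@]23CC[C@H](CC2=O)C3(C)C)CCN1c1ncc(C(F)(F)F)cn1`, has not yet been measured. It is built from compound 1 by methyl in place of hydrogen on a saturated ring carbon. Among the measured compounds shown here, this is the same kind of change as the one from compound 2 to compound 3, but not the same: there the methyl entered a five-membered non-aromatic ring of carbon only within a fused or bridged system, while here it enters a six-membered non-aromatic ring with two nitrogens, next to the ring nitrogen and next to the ring atom that bears a 5-(trifluoromethyl)pyrimidin-2-yl group. For the measured compounds named here, the step from compound 1 to compound 4 in this assay is expected to be about a 1.0-fold higher number from compound 1 to compound 4 (0.01 log units; within the scatter), a small shift like the measured one, because the only comparable change gave a 1.3-fold higher number from compound 2 to compound 3 (0.10 log units; within the scatter). Compound 4 is therefore estimated at 320 nM, likely between 120 nM and 850 nM.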

Compound 4, half-maximal inhibitory concentration: 126 nM
Compound 4: the middle estimate sits 2.5-fold (0.40 log units) above what was measured; the range from low to high includes it.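

In this assay, placing a methyl on a saturated ring carbon of the six-membered ring with two nitrogens gave a 2.5-fold lower number from compound 1 to compound 4 (0.40 log units; beyond the scatter), a modest step towards stronger inhibition. Set beside the earlier methyl step, this shows that the same kind of change does not carry a fixed effect from one core to another in this series: the same change on two cores in this assay, a 1.3-fold higher number (0.10 log units; within the scatter) from compound 2 to compound 3 and a 2.5-fold lower number (0.40 log units; beyond the scatter) from compound 1 to compound 4, 3.2-fold (0.50 log units) apart, beyond the scatter of two such steps

What this does not show is the reason for the gap: the two methyls sit in different rings and on different cores, so place and core cannot be told apart, and two steps make no general rule. The compounds shown leave open whether the same methyl on the ring with two nitrogens would give a similar step on the core of compound 2, a comparison that would help separate place from core. They also leave open what an ethyl, a hydroxymethyl or an amine would do on that same ring carbon.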